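The source may report more compounds than this note shows. Statements on the series, on what has been measured and on what is new or still open speak of the compounds shown alone.

Measured so far in an assay on HEK293 cells for binding affinity to 5-hydroxytryptamine receptor 7 (Homo sapiens), read by radioligand binding; a higher number here means a weaker inhibitor, a lower number a stronger inhibitor:
- compound 1 `CN1CCCN(CCn2ccc3ccc(Br)cc32)CC1`: 31 nM
- compound 2 `CN1CCCN(CCn2ccc3ccc(F)cc32)CC1`: 288 nM
- compound 3 `Cc1ccc2ccn(CCN3CCCN(C)CC3)c2c1`: 125 nM

Compound 3 gives the second highest of the three numbers in this assay. Its nearest neighbour is compound 2, the step of a 2.3-fold lower number from compound 2 to compound 3 (0.36 log units; beyond the scatter) being modest but beyond the scatter; the furthest is compound 1, with a 4.0-fold higher number from compound 1 to compound 3 (0.61 log units; beyond the scatter). Compound 1 stands lowest of the three, and a 9.3-fold higher number from compound 1 to compound 2 (0.97 log units; beyond the scatter) is the largest step seen.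

Compound 4 `CCc1ccc2ccn(CCN3CCCN(C)CC3)c2c1` is not yet measured. It differs from compound 3 by methyl in place of hydrogen on a saturated chain carbon bound to an aromatic carbon; read one bond further out, the group on the aromatic carbon changes from methyl to ethyl.

Among the measured compounds shown here, no measured step alters the group on the saturated chain carbon itself, so none bears on it directly. The steps that come closest exchange the whole group on the aromatic carbon: bromo against methyl, a 4.0-fold higher number from compound 1 to compound 3 (0.61 log units; beyond the scatter), and fluoro against methyl, a 2.3-fold lower number from compound 2 to compound 3 (0.36 log units; beyond the scatter). Both show that the number at this position moves by modest amounts with the group present, and that the largest group, bromo in compound 1, sits lowest. On that basis compound 4 is expected to give a small lowering, a 1.6-fold lower number from compound 3 to compound 4 (0.19 log units; within the scatter), though a result within the scatter of compound 3 would not surprise. The estimate for compound 4 in this assay is 80 nM, within 30 nM to 200 nM.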

Compound 4, inhibition constant: 166 nM
The estimate for compound 4 lay 2.1-fold (0.32 log units) below the measured number, within the range that was stated.
By their numbers in this assay, from the lowest: compound 1; then compounds 3, 4 and 2 (each within the scatter of the next, the first and the last beyond it).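

In this assay, lengthening methyl to ethyl at this aromatic carbon gives a 1.3-fold higher number from compound 3 to compound 4 (0.12 log units; within the scatter), so the first change made on the saturated chain carbon does not separate compound 4 from compound 3. Ethyl is also not separated from fluoro, at a 1.7-fold lower number from compound 2 to compound 4 (0.24 log units; within the scatter), whereas bromo stays apart from ethyl, at a 5.4-fold higher number from compound 1 to compound 4 (0.73 log units; beyond the scatter), which makes compound 1 the only one of the four with steps to all three others beyond the scatter. Nothing available explains why the bromo compound stands apart or why the added methyl changes so little.

Still open, as far as these compounds go, is whether a longer chain such as propyl, or a branched isopropyl group, at the same aromatic carbon would stay within the scatter of compound 3 and compound 4. Also open, from the compounds shown here alone, is whether chloro or iodo would fall with bromo in compound 1, which would show whether halogens other than fluoro share its number, and whether a methoxy group, with an oxygen on the aromatic carbon, would fall with the methyl and ethyl compounds.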